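The source may hold more compounds than are shown below. What is called first, only, known or untested is meant among the compounds shown, and "the series" means these compounds.

Four compounds built on one shared core were examined in an ADME assay on MT4 cells (Homo sapiens) for cytotoxicity; on this read-out higher numbers stand for lower toxicity in this test and lower numbers for higher toxicity in this test. Compound 1 `COc1ccc(-c2nnsc2SCC(=O)Nc2ccccc2Cl)cc1` carries a 4-methoxyphenyl group and a (2-chlorophenyl)amino group. In this assay compound 1 reaches only a limit of > 318000 nM, not a number. Compound 2 `COc1ccc(-c2nnsc2SCC(=O)Nc2ccccc2F)cc1` differs from compound 1 by fluoro in place of chloro on an aromatic carbon. In this assay compound 2 likewise reaches only a limit of > 332000 nM. The step that the two limits leave unreadable from compound 1 to compound 2 cannot be read because the limit of > 318000 nM in this assay, at which 1 of the 3 values shown sits, and the limit of > 332000 nM in this assay, at which 1 of the 3 values shown sits, are both limits rather than numbers. Compound 3 `O=C(CSc1snnc1-c1ccc(F)cc1F)Nc1ccccc1Cl` differs from compound 1 in the core by 2,4-difluorophenyl in place of 4-methoxyphenyl on an aromatic carbon. In this assay, going by the values given here, compound 3 gives 178000 nM, the only plain number among the three compounds measured. Among the compounds with values here, the step of an at least 1.7-fold lower number from compound 1 to compound 3 (0.25 log units; that floor lies within the scatter) is the one readable step, and its floor lies within the usual scatter, so it cannot be called a real difference. Compound 4 `O=C(CSc1snnc1-c1ccc(F)cc1F)Nc1ccccc1F` has not yet been measured; it differs from compound 3 by fluoro in place of chloro on an aromatic carbon, the same change that separates compound 1 from compound 2, made at the same place. That earlier change left no readable step, so the expectation rests on compound 3 alone and its value 178000 nM. Compound 4 is expected to sit close to compound 3, with an estimated step of a 1.0-fold higher number from compound 3 to compound 4 (0.00 log units; within the scatter), a step inside the scatter. The estimate for compound 4 is 180000 nM, expected to fall between 90000 nM and 360000 nM.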

Compound 4, half-maximal cytotoxic concentration: 148000 nM
Beside the measured number, compound 4's estimate is 1.2-fold (0.09 log units) above it, and the stated range covers the measured number.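

The fluoro in place of chloro change now gives a readable result on one core, a 1.2-fold lower number from compound 3 to compound 4 (0.08 log units; within the scatter) in this assay, so the two compounds cannot be told apart in this test, while the same change on the core of compound 1 stays unreadable, and the steps that rest on two limits cannot be read, so nothing can be said about whether this result carries from one core to the other. The change of 2,4-difluorophenyl in place of 4-methoxyphenyl gives an at least 2.2-fold lower number from compound 2 to compound 4 (0.35 log units; beyond the scatter), and it can be set beside the same change made with chloro in place of fluoro on the other core: the same change on two cores in this assay, an at least 1.7-fold lower number (0.25 log units; that floor lies within the scatter) from compound 1 to compound 3 and an at least 2.2-fold lower number (0.35 log units; beyond the scatter) from compound 2 to compound 4; the limit leaves it open whether they differ. Going by these compounds alone, only this second step clears the scatter, so a lower number is secure on one core alone, and with each step starting from a limit rather than a number, the series does not show that the change has the same size on both cores.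

The compounds shown leave open how far the lower number belongs to 2,4-difluorophenyl itself, since a plain phenyl or a 4-chlorophenyl group in that place would be needed to tell. They also leave open what a bromo or methyl group would do in place of chloro and fluoro on the same aromatic ring.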